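The source may hold more compounds than are shown below. What is called first, only, known or untested is meant among the compounds shown, and "the series" means these compounds.

Measured compounds in a functional assay on the whole organism (strain Wistar) for inhibition, with Rattus norvegicus as the target, read by paw edema, with stated times of 1 h and 5 h, at a dose of 20 mg/kg by the oral route; on this read-out higher numbers stand for more inhibition at the one dose given (going by the name of the read-out) and lower numbers for less inhibition:

compound 1, `NS(=O)(=O)c1ccc2nc(N3N=C(c4ccc(Br)cc4)CC3c3ccc(Cl)cc3)sc2c1`: 14%
compound 2, `COc1ccc(C2CC(c3ccc(Cl)cc3)=NN2c2nc3ccc(S(N)(=O)=O)cc3s2)cc1`: 67.7%
compound 3, `Cc1ccc(C2CC(c3ccc(Br)cc3)=NN2c2nc3ccc(S(N)(=O)=O)cc3s2)cc1`: 14%

Compound 2 stands highest of the three numbers in this assay; compound 1 and compound 3 both lie the same distance below it, and that distance is beyond the scatter. Within the data shown here, the one single-point step among the measured compounds, no change at the digits printed from compound 1 to compound 3 (within the scatter), concerns a different ring of the shared core and shows no change.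

Compound 4, `CN(C)c1ccc(C2CC(c3ccc(Cl)cc3)=NN2c2nc3ccc(S(N)(=O)=O)cc3s2)cc1`, is not yet measured. It differs from compound 2 by dimethylamino in place of methoxy on an aromatic carbon.

Among the measured compounds shown here, no measured step touches the position that is changed here, so nothing among the measured compounds tells how large the step from compound 2 to compound 4 in this assay should be, nor in which direction. The only fixed point is that compound 2 itself gives 67.7%. Compound 4 is therefore expected to stay in the region of compound 2, with a wide range; the expected step is a number 17.7 percentage points lower from compound 2 to compound 4 (beyond the scatter). The estimate for compound 4 in this assay is 50%, between 20% and 75%.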

Compound 4, a percentage reported as inhibition, in the whole organism at one dose (the size of the read-out at that dose, not a potency): 14%
Compound 4: the middle estimate sits 36 percentage points above what was measured; measured number outside the range, below it.
By their numbers in this assay, from the lowest: compounds 1, 3 and 4 (each within the scatter of the next); then compound 2.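

In this assay, dimethylamino in place of methoxy gives a number 53.7 percentage points lower from compound 2 to compound 4 (beyond the scatter) and so marks this place, para to a large group, as sensitive to the group it carries. The step is large even though the counts of hydrogen-bond donors and acceptors under the two groups are the same, so those counts alone do not track the read-out in this pair. No measured information on either group accounts for the drop.

Going by these compounds, whether the higher number is specific to methoxy remains open, as does how a hydroxy, ethoxy or primary amine group at this place would read. Also open, on these data alone, is whether the same step would appear with bromo in place of chloro elsewhere on the shared core.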